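The source may report more compounds than this note shows. Statements on the series, on what has been measured and on what is new or still open speak of the compounds shown alone.

Working notes on the thienopyrimidine series at a functional assay on CHO-K1 cells for antagonist activity at adenosine receptor A1 (Homo sapiens), read by a beta-galactosidase reporter and cAMP accumulation, with stated times of 15 min and 6 h; on this read-out lower numbers stand for stronger inhibition and higher numbers for weaker inhibition.

Compound 2 `Cc1nc(-c2nc(N)c3cc(Cc4ccccc4)sc3n2)cs1` gives 263 nM in this assay, the lower of the two numbers recorded so far. Compound 1 `Cc1ccc(-c2nc(N)c3cc(C(C)c4ccccc4)sc3n2)o1` gives 439 nM in this assay, and the gap to compound 2 lies within the scatter of repeat measurements, so the two cannot be ordered. Compound 3 `N#Cc1cccc(-c2nc(N)c3cc(Cc4ccccc4F)sc3n2)c1` returns only a limit in this assay, < 16 nM, as noted under (the limit of < 16 nM in this assay, at which 1 of the 3 values shown sits), and not a number.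

Compound 4 `N#Cc1cccc(-c2nc(N)c3cc(Cc4ccccc4)sc3n2)n1` is not yet measured. It differs from compound 2 in one place: 6-cyanopyridin-2-yl in place of 2-methyl-1,3-thiazol-4-yl on an aromatic carbon. Among the compounds with values here, no measured pair reports this exact change, so its size is read from the neighbours only. Within the data shown here, compound 3, the one aryl-cyano member of the set, sits at the limit < 16 nM, which points toward a lower number for compound 4 than for compound 2, though its benzyl also differs. A step from compound 2 to compound 4 of a 5.8-fold lower number from compound 2 to compound 4 (0.77 log units; beyond the scatter) is expected, beyond the scatter. Compound 4 is estimated at 45 nM, in the range 12 nM to 160 nM.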

Compound 4, inhibition constant: > 1000 nM
Compound 4: a limit, no number (the forecaster's own chance of this, stated with the estimate: 25%); middle value at least 22-fold (1.34 log units) away from the limit.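

Within the data shown here, at the aromatic carbon between two ring nitrogen atoms, 6-cyanopyridin-2-yl in place of 2-methyl-1,3-thiazol-4-yl gives the first one-place step, an at least 3.8-fold higher number from compound 2 to compound 4 (0.58 log units; beyond the scatter), so this position does not treat these two aromatic groups alike. Compound 4 returns only a limit in this assay, not a number: the limit of > 1000 nM in this assay, at which 1 of the 4 values shown sits.
The two groups have the same hydrogen-bond donor and acceptor counts and no net charge, so those counts do not separate them.

The compounds shown do not separate the part played by the nitrile from that of the pyridine ring nitrogen, and compound 3 differs from compound 4 in more than one place, so it cannot settle this. A plain pyridin-2-yl or a 6-methylpyridin-2-yl on this carbon would address that question.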